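A few compounds are considered here, and "the series" means these few. Any claim that something is new, unique, unknown or untested is made for them only; others in the source may bear on it.

Measured so far in a functional assay on DLD-1 cells (Homo sapiens) for cytotoxicity, with a stated time of 48 h; a higher number here means a weaker inhibitor, a lower number a stronger inhibitor:
- compound 1 `CCOc1ccc2oc(/C=C/[S+](C)[O-])cc(=O)c2c1`: 4900 nM
- compound 2 `CCCCC(=O)Oc1ccc2oc(/C=C/[S+](C)[O-])cc(=O)c2c1`: 6700 nM
- compound 3 `CC(C)C(=O)Oc1ccc2oc(/C=C/[S+](C)[O-])cc(=O)c2c1`: 9100 nM

Compound 3 stands within the scatter of both others, with a 1.4-fold higher number from compound 2 to compound 3 (0.13 log units; within the scatter) and a 1.9-fold higher number from compound 1 to compound 3 (0.27 log units; within the scatter) as its steps. Compound 4 `CC(C)Oc1ccc2oc(/C=C/[S+](C)[O-])cc(=O)c2c1` differs from it by one change: isopropyl in place of isopropylcarbonyl on an oxygen on an aromatic ring. Compound 1 also has no carbonyl there, only ethyl on that oxygen. Thus a 1.9-fold higher number from compound 1 to compound 3 (0.27 log units; within the scatter) shows a similar exchange in reverse, as does a 1.4-fold higher number from compound 1 to compound 2 (0.14 log units; within the scatter) and both stay small. A modest move toward a lower number is therefore expected, with nothing beyond the scatter. The expected change is a 1.7-fold lower number from compound 3 to compound 4 (0.22 log units; within the scatter) in this estimate. For compound 4 the estimated value is 5500 nM (expected range 3000 nM to 10000 nM) in this assay when measured.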

Compound 4, half-maximal inhibitory concentration: 8000 nM
Compound 4: middle estimate off by 1.5-fold (0.16 log units), on the low side; the measured number falls inside the stated range.
By their numbers in this assay, from the lowest: compounds 1, 2, 4 and 3 (each within the scatter of the next).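

At this oxygen on an aromatic ring, going from isopropylcarbonyl to isopropyl keeps the alkyl part and removes only the carbonyl, and this gives a 1.1-fold lower number from compound 3 to compound 4 (0.06 log units; within the scatter) in this assay. Among the groups without a carbonyl, one added methyl gives a 1.6-fold higher number from compound 1 to compound 4 (0.21 log units; within the scatter), while isopropyl in place of butylcarbonyl gives a 1.2-fold higher number from compound 2 to compound 4 (0.08 log units; within the scatter), so neither the carbonyl nor these chain changes moves the number beyond the scatter. No measurement here explains this flat result.

From the compounds shown here alone, whether an amine, a carboxylic acid or a longer chain on this oxygen would shift the number beyond the scatter remains open.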